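Benzyl to 4-(tert-Butyl)phenyl: Expected Growth Inhibition

This account rests on a few compounds, and the source may have more. Where it says the series, first, only, none or still open, it means among the compounds named here.

Compound 1 `CCN1CCN(c2ccc(Nc3ncc(Cl)c(Nc4ccccc4C)n3)nc2)CC1`: > 100000 nM, a limit of the assay rather than a number.
Compound 2 `Cc1ccccc1Nc1nc(Nc2ccc(N3CCCCC3)cn2)ncc1Cl`: 42400 nM.
Compound 3 `CN1CCN(c2ccc(Nc3ncc(Cl)c(NCc4ccccc4)n3)nc2)CC1`: 20300 nM.

In an ADME assay on L02 cells (Homo sapiens) for inhibition, read by CCK-8 assay, with a stated time of 48 h (on this read-out lower numbers stand for stronger inhibition of growth and higher numbers for weaker inhibition of growth), compound 3 gives the lowest of the two numbers measured; its nearest neighbour, compound 2, stands higher by more than the usual scatter. Compound 4 `CN1CCN(c2ccc(Nc3ncc(Cl)c(Nc4ccc(C(C)(C)C)cc4)n3)nc2)CC1` differs from compound 3 by 4-(tert-butyl)phenyl in place of benzyl on a nitrogen on an aromatic ring. Among the measured compounds shown here, the only measured step, an at least 2.3-fold lower number from compound 1 to compound 2 (0.37 log units; beyond the scatter), changes a different part of the molecule and so gives no direct guide here. Compound 2, which also carries a phenyl-type group on that nitrogen, sits above compound 3, and compound 1 reaches only the limit (the limit of > 100000 nM in this assay, at which 1 of the 3 values shown sits). A weaker result is therefore expected for compound 4, a 2.2-fold higher number from compound 3 to compound 4 (0.35 log units; beyond the scatter), with an estimated value of 45000 nM (range 15000 nM to 150000 nM).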

Compound 4, concentration for 50% growth inhibition: 6070 nM
Beside the measured number, compound 4's estimate is 7.4-fold (0.87 log units) above it, and the stated range ends above it.
By their numbers in this assay, from the lowest: compound 4; then compound 3; then compound 2. At a limit, above all of these: compound 1.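

In this assay, putting 4-(tert-butyl)phenyl in place of benzyl on this nitrogen gives a 3.3-fold lower number from compound 3 to compound 4 (0.52 log units; beyond the scatter) and so stronger inhibition of growth in these cells. Among the compounds shown here, the earlier step changed a different part of the molecule, so this is the first sign that the group on this nitrogen also moves the read-out. No measurement shown here explains this step.

As far as these compounds go, it remains open whether the tert-butyl group itself matters, which a plain phenyl on this nitrogen would help to test. From the compounds shown here alone, how a phenyl carrying an amine or a carboxylic acid in its place would read also remains open.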